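Shrinking the ring on the core nitrogen: cyclohexyl to cyclobutyl

This account rests on a few compounds, and the source may have more. Where it says the series, first, only, none or still open, it means among the compounds named here.

Measured so far:
- compound 1 `CC(C)c1onc(-c2c(Cl)cccc2Cl)c1COc1ccc(-c2nc3ccc(C(=O)O)cc3n2-c2ccc(F)cc2)cc1`: 2410 nM
- compound 2 `CC(C)c1onc(-c2c(Cl)cccc2Cl)c1COc1ccc(-c2nc3ccc(C(=O)O)cc3n2C2CCCCCC2)cc1`: 921 nM
- compound 3 `CC(C)c1onc(-c2c(Cl)cccc2Cl)c1COc1ccc(-c2nc3ccc(C(=O)O)cc3n2C2CCCCC2)cc1`: 1450 nM

All three share one core and differ only in the group carried on an aromatic nitrogen of that core. In an assay on HEK-293T cells for antagonist activity at vitamin D3 receptor (Homo sapiens), read by a luciferase reporter, with a stated time of 24 h (a higher number here means a weaker inhibitor, a lower number a stronger inhibitor), compound 1, with a 4-fluorophenyl there, gives 2410 nM. Replacing that group by a cycloheptyl gives a 2.6-fold lower number from compound 1 to compound 2 (0.42 log units; beyond the scatter), and replacing it by a cyclohexyl gives a 1.7-fold lower number from compound 1 to compound 3 (0.22 log units; within the scatter). Between the two saturated rings the difference is small: a 1.6-fold higher number from compound 2 to compound 3 (0.20 log units; within the scatter). Compound 3 thus sits in the middle of the three numbers, separated from both neighbours by no more than the usual scatter.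

Compound 4 `CC(C)c1onc(-c2c(Cl)cccc2Cl)c1COc1ccc(-c2nc3ccc(C(=O)O)cc3n2C2CCC2)cc1` continues in the same direction: cyclobutyl in place of cyclohexyl on an aromatic nitrogen. For the measured compounds named here, the only step that bears on it is the one from cycloheptyl to cyclohexyl, which was within the scatter, though it pointed toward a higher number as the ring got smaller. A further, larger cut in ring size is therefore expected to give, at most, a modest rise, a 1.4-fold higher number from compound 3 to compound 4 (0.16 log units; within the scatter), in this assay. Compound 4 is estimated at 2100 nM, with a range from 900 nM to 5000 nM.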

Compound 4, half-maximal inhibitory concentration: 1100 nM
Compound 4: the middle estimate sits 1.9-fold (0.28 log units) above what was measured; the range from low to high includes it.
By their numbers in this assay, from the lowest: compounds 2, 4, 3 and 1 (each within the scatter of the next, the first and the last beyond it).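

Shrinking the saturated ring on the aromatic nitrogen as far as cyclobutyl leaves the number within the scatter in this assay of both larger rings (a 1.3-fold lower number from compound 3 to compound 4 (0.12 log units; within the scatter); a 1.2-fold higher number from compound 2 to compound 4 (0.08 log units; within the scatter)), so the earlier hint that a smaller ring gives a higher number does not carry through to compound 4. Cyclobutyl also stands apart from 4-fluorophenyl (a 2.2-fold lower number from compound 1 to compound 4 (0.34 log units; beyond the scatter)), as cycloheptyl does, while cyclohexyl in compound 3 goes against this picture by staying within the scatter of compound 1. Nothing shown here explains why these rings behave so much alike.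

From the compounds shown here alone, whether a cyclopropyl or an open chain such as isopropyl would fit in with these rings remains open. So does the effect of a ring holding an amine nitrogen, such as piperidine, or of a plain phenyl without its fluorine.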